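Piperidin-1-yl in Place of Dimethylamino on Two Cores

This account rests on a few compounds, and the source may have more. Where it says the series, first, only, none or still open, it means among the compounds named here.

Compound 1 `C/C(=C\CN1CCCCC1)c1ccc(-c2ccccc2)cc1` and compound 2 `C/C(=C\CN(C)C)c1ccc(-c2ccccc2)cc1` share one core, whereas compound 3 `COc1cccc(/C(C)=C/CN(C)C)c1` rests on another; the difference between the two cores is not broken down here. In an assay on cell membranes for displacement of a labelled ligand from Sigma non-opioid intracellular receptor 1 (Cavia porcellus), read by scintillation counting, with a stated time of 150 min (a higher number here means a weaker inhibitor, a lower number a stronger inhibitor), compound 1 gives 0.86 nM, and compound 2 gives 1.4 nM. Compound 3 reaches only a limit in this assay, > 1000 nM, which is a limit of the assay and not a number (the limit of > 1000 nM in this assay, at which 1 of the 3 values shown sits). The change from compound 2 to compound 1, (piperidin-1-yl in place of dimethylamino on a saturated chain carbon bound to a double-bonded chain carbon), made a 1.6-fold lower number from compound 2 to compound 1 (0.21 log units; within the scatter). Compound 4 `COc1cccc(/C(C)=C/CN2CCCCC2)c1` carries the same change on the core of compound 3, (piperidin-1-yl in place of dimethylamino on a saturated chain carbon bound to a double-bonded chain carbon). Because compound 3 already sits at the limit of > 1000 nM in this assay, at which 1 of the 3 values shown sits, and the measured step of a 1.6-fold lower number from compound 2 to compound 1 (0.21 log units; within the scatter) stayed within the scatter, compound 4 is expected to remain weak, with a step that the limit leaves unreadable from compound 3 to compound 4 estimated. Compound 4 is therefore expected to give 1500 nM, between 500 nM and 5000 nM.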

Compound 4, inhibition constant: 91 nM
Estimate against measurement, compound 4: 16-fold (1.22 log units) above; the measured number lies below the stated range.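

In this assay, piperidin-1-yl in place of dimethylamino on a saturated chain carbon bound to a double-bonded chain carbon gave an at least 10-fold lower number from compound 3 to compound 4 (1.04 log units; beyond the scatter), so the size of the step did not carry over from one core to the other: the same change on two cores in this assay, a 1.6-fold lower number (0.21 log units; within the scatter) from compound 2 to compound 1 and an at least 10-fold lower number (1.04 log units; beyond the scatter) from compound 3 to compound 4, at least 6.7-fold (0.82 log units) apart, beyond the scatter of two such steps. As far as these compounds go, compound 3 stands at a limit of the assay, > 1000 nM, which is not a number, so the full size of this step stays unknown. The two pairs show that the step depends on the core, but not why, and they give no rule for any other core.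

The compounds shown leave open how pyrrolidin-1-yl or morpholin-4-yl would fare in the same place on either core. They also leave open whether a longer chain carrying piperidin-1-yl would behave alike.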